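The source may report more compounds than this note shows. Statements on the series, on what has been measured and on what is new or still open speak of the compounds shown alone.

Measured so far, in a functional assay on MOLT-4 cells (Homo sapiens) for inhibition, read by MTT assay, with a stated time of 48 h; on this read-out lower numbers stand for stronger inhibition and higher numbers for weaker inhibition:
compound 1, `O=C(/C=C/c1ccccc1)c1ccc[nH]1`, gives > 100000 nM;
compound 2, `O=C(/C=C/c1cccc([N+](=O)[O-])c1)c1ccc[nH]1`, gives 22000 nM;
compound 3, `COc1cccc(/C=C/C(=O)c2ccc[nH]2)c1`, gives 28000 nM.

The value of compound 1 is a limit of this assay, not a number. Among the two numbers shown, compound 2 holds the lowest, and compound 3 sits nearest to it; their gap, a 1.3-fold higher number from compound 2 to compound 3 (0.10 log units; within the scatter), lies within the usual scatter, so neither can be called the stronger of the two.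

Compound 4, `O=C(/C=C/c1cc([N+](=O)[O-])ccc1Cl)c1ccc[nH]1`, is not yet measured. It differs from compound 2 by chloro in place of hydrogen on an aromatic carbon. Among the measured compounds shown here, no measured step here replaces a hydrogen with chloro, so the bearing of the earlier steps is only indirect. Both measured changes to the ring, an at least 4.5-fold lower number from compound 1 to compound 2 (0.65 log units; beyond the scatter) and an at least 3.5-fold lower number from compound 1 to compound 3 (0.55 log units; beyond the scatter), lowered the number when a group was put onto the bare ring of compound 1; that the limit sits at the limit of > 100000 nM in this assay, at which 1 of the 3 values shown sits, means the true size of these steps is not known. For the measured compounds named here, a second group added to a ring that already carries nitro has no precedent in these data. Compound 4 is therefore expected to give a number close to that of compound 2, with a step of a 1.5-fold lower number from compound 2 to compound 4 (0.17 log units; within the scatter) that is expected to stay within or only slightly beyond the scatter. The estimate for compound 4 is 15000 nM, with a range from 5000 nM to 50000 nM.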

Compound 4, half-maximal inhibitory concentration: 42000 nM
Beside the measured number, compound 4's estimate is 2.8-fold (0.45 log units) below it, within the range that was stated.
By their numbers in this assay, from the lowest: compounds 2, 3 and 4 (each within the scatter of the next). At a limit, above all of these: compound 1.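

In this assay, chloro in place of hydrogen, on the aromatic carbon ortho to a group of 9 heavy atoms and para to a nitro group, gives a 1.9-fold higher number from compound 2 to compound 4 (0.28 log units; within the scatter). Among the compounds shown here, compound 4 is the first compound here with a chloro and the first with two groups on this six-membered ring, and this step shows that adding chloro at this position to the nitro-bearing ring of compound 2 leaves the result within the usual scatter, so the two compounds cannot be told apart. The size of this step cannot be set against the earlier steps that start from compound 1, because the value of compound 1 is a limit and not a number: the limit of > 100000 nM in this assay, at which 1 of the 4 values shown sits.

As far as these compounds go, it remains open whether a fluoro, a methyl or an amine on this same carbon would also stay within the scatter of compound 2. Also open, from the compounds shown here alone, is whether chloro at this place would give a readable value on the bare ring of compound 1, with no nitro present.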